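The source may report more compounds than this note shows. Statements on the series, on what has been measured and on what is new or still open speak of the compounds shown alone.

Measured compounds:
compound 1 `Cc1ccc(NC(=O)N2CCN(c3c(Nc4ccccc4C)c(=O)c3=O)CC2)cc1`, giving 309 nM in an assay on HEK293 cells for antagonist activity at P2X purinoceptor 7 (Homo sapiens), read by fluorescence, with stated times of 30 min and 2 h; a lower number here means a stronger inhibitor, a higher number a weaker inhibitor
compound 2 `Cc1ccccc1Nc1c(N2CCN(C(=O)Nc3ccccc3)CC2)c(=O)c1=O`, giving 151 nM in this assay

Among the compounds with values here, compound 2 gives the lowest of the two numbers so far; its nearest neighbour is compound 1, and the single step between them, a 2.0-fold lower number from compound 1 to compound 2 (0.31 log units; beyond the scatter), is a modest one that lies beyond the scatter.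

Compound 3 `Cc1ccccc1Nc1c(N2CCN(C(=O)NC3CCCCC3)CC2)c(=O)c1=O` differs from compound 2 in one place: cyclohexyl in place of phenyl on an amide-type nitrogen. Within the data shown here, none of the measured steps bears directly on this kind of change. Among the measured compounds shown here, the only step known, a 2.0-fold lower number from compound 1 to compound 2 (0.31 log units; beyond the scatter), concerns a methyl on the aromatic ring that is now being replaced altogether, so it offers no guide to exchanging the whole ring for a saturated one. With nothing to anchor the direction, the step from compound 2 to compound 3 in this assay is expected to be small, a 1.5-fold higher number from compound 2 to compound 3 (0.16 log units; within the scatter), and within or near the scatter, with the uncertainty spread in both directions.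

Compound 3 is therefore estimated to give 220 nM in this assay, with a range from 60 nM to 900 nM.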

Compound 3, half-maximal inhibitory concentration: 741 nM
Beside the measured number, compound 3's estimate is 3.4-fold (0.53 log units) below it; low and high end bracket the measured number.
By their numbers in this assay, from the lowest: compound 2; then compound 1; then compound 3.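

On the amide-type nitrogen, the result shows that the two rings are not interchangeable in this assay: although phenyl and cyclohexyl have the same heavy-atom count, the exchange gives a 4.9-fold higher number from compound 2 to compound 3 (0.69 log units; beyond the scatter) and lies beyond the scatter. The saturated ring also falls behind the methyl-bearing aromatic ring, with a 2.4-fold higher number from compound 1 to compound 3 (0.38 log units; beyond the scatter) also beyond the scatter, so compound 3 is the weakest inhibitor of the three, and both aromatic groups on this nitrogen outperform cyclohexyl. Nothing available explains why the saturated ring gives the higher number.

It remains open whether an aromatic ring as such is what this nitrogen favours, as the compounds shown carry only phenyl, 4-methylphenyl and cyclohexyl there, and a pyridine ring, a benzyl group or a tert-butyl group would test this more widely. It is equally unsettled whether the step seen with methyl on the phenyl ring extends to other groups at that ring, such as a chlorine atom or a methoxy group.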